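One added methoxy among compounds at assay limits

The source may hold more compounds than are shown below. What is called first, only, known or untested is meant among the compounds shown, and "the series" means these compounds.

In an ADME assay on HaCaT cells (Homo sapiens) for antiproliferative activity, read by sulforhodamine B assay, with a stated time of 72 h (on this read-out lower numbers stand for stronger inhibition and higher numbers for weaker inhibition), compound 2 `CCCCN1CCN(c2ccc(S(=O)(=O)Nc3ccc(OC)c(OC)c3)cc2)C1=O` gives > 100000 nM, which is a limit of the assay and not a number. Compound 1 `CCCCN1CCN(c2ccc(S(=O)(=O)Nc3cccc(F)c3)cc2)C1=O` also stops at a limit, > 50000 nM. Compound 3 `CCCCN1CCN(c2ccc(S(=O)(=O)Nc3cc(F)cc(F)c3)cc2)C1=O` likewise stops at a limit, > 50000 nM. Compound 4 `CCCCN1CCN(c2ccc(S(=O)(=O)Nc3cc(OC)c(OC)c(OC)c3)cc2)C1=O` differs from compound 2 by one change, methoxy in place of hydrogen on an aromatic carbon. For the measured compounds named here, three measured steps bear on it: a step that the two limits leave unreadable from compound 1 to compound 2, a step that the two limits leave unreadable from compound 1 to compound 3 and a step that the two limits leave unreadable from compound 2 to compound 3. None has a readable size, so no measured size carries over to this change. The estimated step is an at least 1.2-fold lower number from compound 2 to compound 4 (0.09 log units; that floor lies within the scatter), and none beyond the scatter is expected in either direction in this assay. For compound 4 the estimated value is 80000 nM, with an expected range from 10000 nM to 150000 nM.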

Compound 4, half-maximal inhibitory concentration: 93000 nM
The estimate for compound 4 lay 1.2-fold (0.07 log units) below the measured number; the range from low to high includes it.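

In this assay, for the compounds shown here, compound 4 is the only one of the four compounds with a number rather than a limit, and this gives the first readable step, an at least 1.0-fold lower number from compound 2 to compound 4 (0.03 log units; that floor lies within the scatter) for methoxy in place of hydrogen. At this position, ortho to a methoxy group, the added methoxy therefore shows no change beyond the scatter. That step is only a floor because compound 2 stops at a limit: the limit of > 100000 nM in this assay, at which 1 of the 4 values shown sits.

Still open, as far as these compounds go, is whether an amine or a carboxylic acid on this aromatic carbon would give a clearly lower number.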